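This account rests on a few compounds, and the source may have more. Where it says the series, first, only, none or still open, it means among the compounds named here.

For the measured compounds named here, in a functional assay on HT-29 cells (Homo sapiens) for cytotoxicity, read by MTT assay, with a stated time of 72 h (on this read-out higher numbers stand for weaker inhibition and lower numbers for stronger inhibition), compound 2 `COc1cc2c(Oc3ccc(NC(=O)c4cn(-c5ccccc5C)nn4)cc3F)ccnc2cc1OCCCN1CCCC1` gives 1200 nM, the highest of the two numbers so far; compound 1 `COc1cc2c(Oc3ccc(NC(=O)c4cn(-c5ccccc5Cl)nn4)cc3F)ccnc2cc1OCCCN1CCCC1` gives 150 nM. Going by the values given here, the only measured step is an 8.0-fold higher number from compound 1 to compound 2 (0.90 log units; beyond the scatter). Compound 3 `COc1cc2c(Oc3ccc(NC(=O)c4cn(-c5ccc(Br)cc5)nn4)cc3F)ccnc2cc1OCCCN1CCCC1` has not been measured; it differs from compound 2 by 4-bromophenyl in place of 2-methylphenyl on an aromatic nitrogen. Among the compounds with values here, no measured step covers this exact change; the one known step, chloro to methyl, suggests that a halogen on this ring goes with a lower number, though the two halogens are not at the same position, so the expectation is uncertain. For compound 3 the estimate in this assay is 300 nM, range 60 nM to 1500 nM. The expected step is a 4.0-fold lower number from compound 2 to compound 3 (0.60 log units; beyond the scatter).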

Compound 3, half-maximal inhibitory concentration: 190 nM
Compound 3: middle estimate off by 1.6-fold (0.20 log units), on the high side; the range from low to high includes it.
By their numbers in this assay, from the lowest: compounds 1 and 3 (each within the scatter of the next); then compound 2.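

In this assay, 4-bromophenyl in place of 2-methylphenyl on the aromatic nitrogen gives a 6.3-fold lower number from compound 2 to compound 3 (0.80 log units; beyond the scatter), so this position tolerates a halogen at a second ring location, and the gap is not specific to 2-chlorophenyl. With a 1.3-fold higher number from compound 1 to compound 3 (0.10 log units; within the scatter), 2-chlorophenyl and 4-bromophenyl cannot be told apart here, leaving compound 2 alone at the higher number. Nothing available on these compounds explains the difference.

Still open, from the compounds shown here alone, is whether the halogen itself or the ring location of the substituent governs the number. A 4-methylphenyl or an unsubstituted phenyl on the same nitrogen would bear on this.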